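The compounds below may be only part of what the source reports. "The series", "measured", "known", "first", "only" and "open" are said of these compounds alone.

Three compounds that share one core, differing only in the ester group attached to it, have been measured so far. Compound 1 `CC(C)=CC[C@@H](OC(=O)CCO)C1=CC(=O)c2c(O)ccc(O)c2C1=O` gives 55300 nM in a functional assay on DU-145 cells (Homo sapiens) for cytotoxicity, read by MTT assay; a higher number here means a weaker inhibitor, a lower number a stronger inhibitor. Compound 2 `CC(=O)OCCC(=O)O[C@H](CC=C(C)C)C1=CC(=O)c2c(O)ccc(O)c2C1=O` gives 15700 nM in this assay, and compound 3 `CC(C)=CC[C@@H](OC(=O)C1CCCO1)C1=CC(=O)c2c(O)ccc(O)c2C1=O` gives 10500 nM. Compound 3 thus has the lowest of the three numbers, although compound 2 sits close enough that the two cannot be told apart, while compound 1 is clearly further away.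

Compound 4 `CC(C)=CC[C@@H](OC(=O)c1ccoc1)C1=CC(=O)c2c(O)ccc(O)c2C1=O` is the next compound, and it differs from compound 3 at the group on the carbonyl carbon: furan-3-yl in place of oxolan-2-yl on a carbonyl carbon. The measured steps at that same position were a 5.3-fold lower number from compound 1 to compound 3 (0.72 log units; beyond the scatter) and a 1.5-fold lower number from compound 2 to compound 3 (0.17 log units; within the scatter): the first one modest, the second one within the scatter. Neither of them swaps a saturated ring for an aromatic one, so they give only a rough guide, and the expected step for compound 4 is therefore a 1.1-fold lower number from compound 3 to compound 4 (0.02 log units; within the scatter), no clear change beyond the scatter. Compound 4 is expected to give about 10000 nM in this assay, within a range of 4000 nM to 25000 nM.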

Compound 4, half-maximal inhibitory concentration: > 100000 nM
Compound 4: a limit, no number (the forecaster's own chance of this, stated with the estimate: 5%); middle value at least 10-fold (1.00 log units) away from the limit.
By their numbers in this assay, from the lowest: compounds 3 and 2 (each within the scatter of the next); then compound 1. At a limit, above all of these: compound 4.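

The ring at this position matters more than its size: furan-3-yl and oxolan-2-yl have the same counts of heavy atoms and hydrogen-bond acceptors, yet the aromatic ring in place of the non-aromatic one gives an at least 9.5-fold higher number from compound 3 to compound 4 (0.97 log units; beyond the scatter). The 2-acetoxyethyl chain is also separated from furan-3-yl, with an at least 6.3-fold higher number from compound 2 to compound 4 (0.80 log units; beyond the scatter), whereas the comparison with 2-hydroxyethyl gives only an at least 1.8-fold higher number from compound 1 to compound 4 (0.25 log units; that floor lies within the scatter), so no clear separation can be claimed there. The result for compound 4 in this assay is a limit, not a number: the limit of > 100000 nM in this assay, at which 1 of the 4 values shown sits.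

The compounds shown cannot tell whether aromaticity or the ring's point of attachment matters, as both differ between furan-3-yl and oxolan-2-yl. Furan-2-yl would address that question, while phenyl or an amine on the same carbonyl carbon remains an open case.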